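Moving the fluorine: from compound 2 to compound 3

A few compounds are considered here, and "the series" means these few. Any claim that something is new, unique, unknown or untested is made for them only; others in the source may bear on it.

Measured so far in an ADME assay on Vero 76 cells (Chlorocebus sabaeus) for cytotoxicity, read by MTT assay, with a stated time of 96 h; on this read-out higher numbers stand for lower toxicity in this test and lower numbers for higher toxicity in this test:
- compound 1 `NS(=O)(=O)c1ccc(N2N=C(c3ccccc3)CC2c2ccccc2F)cc1` gives 28000 nM
- compound 2 `NS(=O)(=O)c1ccc(N2N=C(c3ccc(OCc4ccccc4)cc3)CC2c2ccc(F)cc2)cc1` gives 90000 nM

Compound 2 holds the higher of the two numbers, and the gap to compound 1 lies beyond the scatter. Compound 3 `NS(=O)(=O)c1ccc(N2N=C(c3ccc(OCc4ccccc4)cc3)CC2c2ccccc2F)cc1` carries 2-fluorophenyl in place of 4-fluorophenyl on a saturated ring carbon. Going by the values given here, no measured pair isolates this change. Compound 1 also carries 2-fluorophenyl and gives 28000 nM but differs elsewhere too, so only a slight lean downward is assumed. The expected 1.5-fold lower number from compound 2 to compound 3 (0.18 log units; within the scatter) stays within the scatter. The estimated value for compound 3 is 60000 nM (expected range 25000 nM to 100000 nM).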

Compound 3, half-maximal cytotoxic concentration: > 100000 nM
Compound 3 ended at the assay's limit; the forecaster's own chance of this, stated with the estimate: 30%; at least 1.6-fold (0.22 log units) between middle value and limit.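

In this assay compound 3 gives > 100000 nM, which is a limit and not a number: the limit of > 100000 nM in this assay, at which 1 of the 3 values shown sits. The change to 2-fluorophenyl on the saturated ring carbon gives an at least 1.1-fold higher number from compound 2 to compound 3 (0.04 log units; that floor lies within the scatter), so this position does not separate the two fluorophenyl groups here. Going by these compounds alone, with 2-fluorophenyl held, benzyloxy in place of hydrogen gives an at least 3.5-fold higher number from compound 1 to compound 3 (0.55 log units; beyond the scatter), the first single-place step that clears the scatter.

From the compounds shown here alone, the size of both steps remains unknown past the limit. Also open, going by these compounds, is how this assay reads with an amine or a carboxylic acid in place of benzyloxy.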